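The source may hold more compounds than are shown below. What is called first, only, known or untested is meant among the compounds shown, and "the series" means these compounds.

Compound 1 `CC(C)CCn1ccc(N2CCCC(c3ccccc3)C2)c(C#N)c1=O`: in a functional assay on CHO cells for positive allosteric modulation of metabotropic glutamate receptor 2 (Homo sapiens), with a stated time of 30 min (on this read-out lower numbers stand for smaller maximal responses and higher numbers for larger maximal responses), compound 1 gives 231%
Compound 2 `N#Cc1c(N2CCC(c3ccccc3)CC2)ccn(CCCC(F)(F)F)c1=O`: compound 2 gives 302%
Compound 3 `N#Cc1c(N2CCC(c3ccc(F)cc3)CC2)ccn(CC2CC2)c1=O`: compound 3 gives 258%

Among these three numbers compound 3 stands second highest. Its nearest neighbour is compound 1, whose maximal response lies lower by a gap beyond the usual scatter; compound 2 lies higher, also by a gap beyond the scatter. For the measured compounds named here, no single-change step between two measured compounds is available, so none of these gaps can be tied to one structural feature.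

Compound 4 `N#Cc1c(N2CCC(c3cc(F)cc(F)c3)CC2)ccn(CC2CC2)c1=O` has not yet been measured. It differs from compound 3 in one place: 3,5-difluorophenyl in place of 4-fluorophenyl on a saturated ring carbon. Going by the values given here, no measured pair shows what a second fluorine on that ring does to the maximal response in this assay. Compound 4 is therefore expected to stay close to compound 3, with a step of a number 8 percentage points lower from compound 3 to compound 4 (within the scatter) that is estimated to lie within the scatter and in no particular direction. The maximal response of compound 4 in this assay is expected at 250%, with an estimated range from 190% to 320%.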

Compound 4, largest response reached (Emax), in percent of the reference or control that the assay uses: 234%
Compound 4: middle estimate off by 16 percentage points, on the high side, and the stated range covers the measured number.
By their numbers in this assay, from the lowest: compounds 1 and 4 (each within the scatter of the next); then compound 3; then compound 2.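

In this assay, for the compounds shown here, the change to 3,5-difluorophenyl on this saturated ring carbon gives a number 24 percentage points lower from compound 3 to compound 4 (beyond the scatter) and is the first difference that can be tied to one structural change. Going by these compounds alone, it shows that the maximal response at this position depends on the fluorine pattern of the phenyl group, although the step is modest and the single change both removes the 4-fluoro pattern and introduces the 3,5-difluoro pattern. Nothing available explains why the response falls.

The compounds shown do not separate the effect of adding a second fluorine from that of relocating the first. They also leave open how an unsubstituted phenyl, a chlorophenyl or a pyridyl group would behave on this carbon with the rest of compound 3 unchanged.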